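Replacing fluoro with methoxy in compound 2

The source may report more compounds than this note shows. Statements on the series, on what has been measured and on what is new or still open speak of the compounds shown alone.

Measured so far in an ADME assay on BEAS-2B cells (Homo sapiens) for cytotoxicity, read by fluorescence, with a stated time of 48 h; on this read-out higher numbers stand for lower toxicity in this test and lower numbers for higher toxicity in this test:
compound 1 `Cc1ccccc1NC(=O)c1cc2n(n1)CCCN(C(=O)c1occc1C)C2` gives 1100 nM
compound 2 `Cc1ccoc1C(=O)N1CCCn2nc(C(=O)Nc3ccc(F)cc3)cc2C1` gives 90000 nM

Of the two, compound 2 has the highest number in this assay and so the lower toxicity in this test. The next compound is compound 3 `COc1ccc(NC(=O)c2cc3n(n2)CCCN(C(=O)c2occc2C)C3)cc1`, which carries methoxy in place of fluoro on an aromatic carbon, para to a large group (methoxy in place of fluoro on an aromatic carbon). For the measured compounds named here, one measured step bears on this change: an 82-fold higher number from compound 1 to compound 2 (1.91 log units; beyond the scatter) and it altered the same aromatic ring. Going by the values given here, no measured step exchanges fluoro for methoxy, so that large step shows only that this ring can move the number widely. With compound 2 at 90000 nM as the top of the numbers seen, a downward move seems likelier. The expected size is a 3.0-fold lower number from compound 2 to compound 3 (0.48 log units; beyond the scatter) and so a modest step down. For compound 3 the expected value is 30000 nM with an estimated range of 8000 nM to 110000 nM around it.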

Compound 3, half-maximal cytotoxic concentration: 90000 nM
The estimate for compound 3 lay 3.0-fold (0.48 log units) below the measured number; measured number inside the range.
By their numbers in this assay, from the lowest: compound 1; then compounds 2 and 3 (each within the scatter of the next).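

In this assay, methoxy in place of fluoro on the aromatic carbon, para to a large group, gives no change at the digits printed from compound 2 to compound 3 (within the scatter), so this position tolerates the exchange of these two groups without a change that can be told from the scatter. The second new comparison, an 82-fold higher number from compound 1 to compound 3 (1.91 log units; beyond the scatter), shows that the wide move first seen with 4-fluorophenyl also appears with 4-methoxyphenyl and does not depend on fluoro alone. No measurement offers a reason why the two groups read alike.

Still open, on these data alone, is whether a methyl group para to the large group would keep the number of compound 2 and compound 3 or fall toward that of compound 1. As far as these compounds go, it is also open whether an amine or a carboxylic acid at this place would move the number at all.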